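The compounds below may be only part of what the source reports. "The series", "measured", "known", "first", "only" and "open" are said of these compounds alone.

Three compounds built on one shared core differ only in the group attached to a sulfonyl sulfur. Compound 1 `O=C(c1ccc(Cl)c(C(F)(F)F)c1)N1CCC(n2cncc2-c2ccc(OS(=O)(=O)c3cccc4ccccc34)cc2)CC1` carries naphthalen-1-yl there, and in an assay on HEK293 cells for antagonist activity at P2X purinoceptor 7 (Homo sapiens), read by fluorescence, with a stated time of 2 h (on this read-out higher numbers stand for weaker inhibition and lower numbers for stronger inhibition), compound 1 gives 3520 nM. Compound 2 `N#Cc1cccc(S(=O)(=O)Oc2ccc(-c3cncn3C3CCN(C(=O)c4ccc(Cl)c(C(F)(F)F)c4)CC3)cc2)c1` carries 3-cyanophenyl instead, and in this assay compound 2 gives 73 nM. Compound 3 `CNC(=O)c1cccc(S(=O)(=O)Oc2ccc(-c3cncn3C3CCN(C(=O)c4ccc(Cl)c(C(F)(F)F)c4)CC3)cc2)c1` carries 3-(methylcarbamoyl)phenyl, and in this assay compound 3 gives 112 nM, the second highest of the three numbers; it sits close to compound 2, since a 1.5-fold higher number from compound 2 to compound 3 (0.19 log units; within the scatter), and far from compound 1, since a 31-fold lower number from compound 1 to compound 3 (1.50 log units; beyond the scatter).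

Compound 4 `O=C(c1ccc(Cl)c(C(F)(F)F)c1)N1CCC(n2cncc2-c2ccc(OS(=O)(=O)c3cccc4cnccc34)cc2)CC1` has not yet been measured. Its change from compound 3 is isoquinolin-5-yl in place of 3-(methylcarbamoyl)phenyl on a sulfonyl sulfur. Within the data shown here, two measured steps bear on this: a 48-fold lower number from compound 1 to compound 2 (1.68 log units; beyond the scatter) and a 31-fold lower number from compound 1 to compound 3 (1.50 log units; beyond the scatter), both showing that a smaller group in place of naphthalen-1-yl gave a much lower number. Compound 4 moves the other way, back to a group resembling naphthalen-1-yl, though one that now holds a nitrogen in its second ring. In this assay the expected step is therefore a 7.1-fold higher number from compound 3 to compound 4 (0.85 log units; beyond the scatter), toward a higher number, with the effect of that nitrogen unknown from these three compounds. Compound 4 is estimated at 800 nM, with a range from 150 nM to 4000 nM.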

Compound 4, half-maximal inhibitory concentration: 45 nM
Estimate against measurement, compound 4: 18-fold (1.25 log units) above, and the stated range ends above it.
By their numbers in this assay, from the lowest: compounds 4, 2 and 3 (each within the scatter of the next, the first and the last beyond it); then compound 1.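

In this assay, the change to isoquinolin-5-yl gives a 78-fold lower number from compound 1 to compound 4 (1.89 log units; beyond the scatter), so a group of two rings on the sulfonyl sulfur can go with a low number, and the high number of compound 1 does not follow from having two rings alone. Measured against the one-ring groups, the picture is mixed: there is a 2.5-fold lower number from compound 3 to compound 4 (0.40 log units; beyond the scatter), which is modest but beyond the scatter, while a 1.6-fold lower number from compound 2 to compound 4 (0.21 log units; within the scatter) lies within the scatter, so compound 2 and compound 4 cannot be told apart here. Among these compounds, the earlier compounds had naphthalen-1-yl as their only two-ring group, and compound 4 now shows that this position can also hold a two-ring group with a number in the same range as compound 2.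

Nothing available here explains why isoquinolin-5-yl and naphthalen-1-yl go with such different numbers. Still open, from the compounds shown here alone, is whether the place of the ring nitrogen matters, as quinolin-5-yl or isoquinolin-8-yl on the same sulfur would test, and how a phenyl group carrying a carboxylic acid or an amine would compare.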